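Quinolone amide series: bromo-fluorophenyl swap on the aromatic nitrogen

This account rests on a few compounds, and the source may have more. Where it says the series, first, only, none or still open, it means among the compounds named here.

Measured so far:
compound 1 `O=C(Nc1ccc(Oc2ccnc3[nH]ccc23)cc1)c1cn(-c2ccc(Br)cc2F)c2ccccc2c1=O` — 1330 nM
compound 2 `Cn1ccc2c(Oc3ccc(NC(=O)c4cn(-c5ccc(F)cc5)c5ccccc5c4=O)cc3F)ccnc21` — 1460 nM

Both numbers come from a functional assay on A549 cells (Homo sapiens) for inhibition, read by MTT assay, with a stated time of 72 h; a lower number here means a stronger inhibitor, a higher number a weaker inhibitor. Compound 1 gives 1330 nM in this assay; compound 2 gives 1460 nM. Compound 2 holds the higher of the two numbers, but the gap to compound 1 lies within the scatter, so no order between them can be read. Among the measured compounds shown here, compound 1 and compound 2 differ in more than one place, and no single step between them is available.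

Compound 3 `Cn1ccc2c(Oc3ccc(NC(=O)c4cn(-c5ccc(Br)cc5F)c5ccccc5c4=O)cc3F)ccnc21` keeps the core of compound 2 and carries the change (4-bromo-2-fluorophenyl in place of 4-fluorophenyl on an aromatic nitrogen). Compound 1 already carries the 4-bromo-2-fluorophenyl group on its own core, and its value in this assay sits within the scatter of compound 2. On that basis no step beyond the scatter is expected for a 1.2-fold lower number from compound 2 to compound 3 (0.09 log units; within the scatter). Compound 3 is estimated at 1200 nM, with a range from 500 nM to 2900 nM.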

Compound 3, half-maximal inhibitory concentration: 1520 nM
The estimate for compound 3 lay 1.3-fold (0.10 log units) below the measured number, and the stated range covers the measured number.
By their numbers in this assay, from the lowest: compounds 1, 2 and 3 (each within the scatter of the next).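

In this assay, among the compounds shown here, 4-bromo-2-fluorophenyl in place of 4-fluorophenyl on the aromatic nitrogen gives a 1.0-fold higher number from compound 2 to compound 3 (0.02 log units; within the scatter) and is the first single-place step. On the core of compound 2, this position therefore carries either aryl group with no readable change in the number, something the pair of compound 1 and compound 2 could not show because they differ in more than one place. No measurement available here offers an explanation for this result.

The bromine and the added fluorine enter together, so their separate contributions, including any that offset each other, stay unresolved. On these data alone, it also remains open whether a non-aryl group on this nitrogen, such as a methyl, or a phenyl ring carrying an amine or a carboxylic acid, would shift the number beyond the scatter.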